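The source may hold more compounds than are shown below. What is called first, only, known or untested is meant among the compounds shown, and "the series" means these compounds.

Measured so far in a functional assay on PC-3 cells (Homo sapiens) for cytotoxicity, read by MTT assay, with a stated time of 48 h; a lower number here means a stronger inhibitor, a higher number a weaker inhibitor:
- compound 1 `CC1=NN(C(=O)CCc2ccccc2)C(c2cc(Br)ccc2O)C1`: 16300 nM
- compound 2 `CC(=O)Oc1ccccc1C1CC(C)=NN1C(=O)CN1CCC(C(C)=O)CC1`: 6800 nM
- compound 3 `O=C(c1ccccc1Cl)N1N=C(c2cc3ccccc3oc2=O)CC1c1ccccc1`: 6370 nM

Compound 3 holds the lowest number of the three in this assay, though its gap to compound 2 lies within the scatter; only its gap to compound 1 lies beyond it. Compound 4 `CC(C)(C)NCC(=O)N1N=C(c2cc3ccccc3oc2=O)CC1c1ccccc1` differs from compound 3 by a single change: ((tert-butyl)amino)methyl in place of 2-chlorophenyl on a carbonyl carbon. Among the compounds with values here, no measured pair shows this change, so the step is unanchored. Compound 2 also carries a chain with an amine on its carbonyl, and in this assay compound 2 gives 6800 nM. Compound 4 is therefore expected to land near compound 3, with a step from a 1.3-fold higher number from compound 3 to compound 4 (0.10 log units; within the scatter), no clear direction beyond the scatter. The estimate for compound 4 is 8000 nM, within 2500 nM to 25000 nM.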

Compound 4, half-maximal inhibitory concentration: 16400 nM
Beside the measured number, compound 4's estimate is 2.1-fold (0.31 log units) below it; the range from low to high includes it.
By their numbers in this assay, from the lowest: compounds 3 and 2 (each within the scatter of the next); then compounds 1 and 4 (each within the scatter of the next).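

On the carbonyl carbon bonded to the amide-type ring nitrogen, the group is not interchangeable in this assay: ((tert-butyl)amino)methyl in place of 2-chlorophenyl gives a 2.6-fold higher number from compound 3 to compound 4 (0.41 log units; beyond the scatter), a modest loss of potency. Within the data shown here, this single-place pair is the only reading of this position, as the earlier compounds offered no such comparison. Nothing available explains the step.

As far as these compounds go, whether the loss follows the departure of the aromatic ring or the arrival of the amine remains open. An unsubstituted phenyl, a benzyl or a morpholinomethyl group at this carbonyl would help separate the two.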